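Thiosemicarbazone series: naphthyl ether swap on the fluoro analogue

The source may hold more compounds than are shown below. What is called first, only, known or untested is meant among the compounds shown, and "the series" means these compounds.

Measured so far in a physicochemical assay for lipophilicity, in phosphate buffer, measured as octanol-water partition, with a stated time of 24 h; a higher number here means a more lipophilic compound, a lower number a more polar compound:
compound 1 `Cc1ccc(Oc2ccc(/C=N/NC(=S)Nc3ccc(Br)cc3)cc2)cc1` gives 6.17
compound 2 `S=C(N/N=C/c1ccc(Oc2ccc3ccccc3c2)cc1)Nc1ccc(Br)cc1` gives 6.93
compound 3 `Cc1ccc(Oc2ccc(/C=N/NC(=S)Nc3ccc(F)cc3)cc2)cc1` gives 5.48

Compound 3 holds the lowest of the three numbers in this assay; the nearest is compound 1 and the furthest compound 2, both higher by amounts beyond the scatter. Among the compounds with values here, the step from compound 1 to compound 3 in this assay is a number 0.69 log units lower from compound 1 to compound 3 (beyond the scatter), the only change there being fluoro in place of bromo on an aromatic carbon.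

Compound 4 `Fc1ccc(NC(=S)N/N=C/c2ccc(Oc3ccc4ccccc4c3)cc2)cc1` is not yet measured. It differs from compound 3 in one place: naphthalen-2-yl in place of 4-methylphenyl on an oxygen on an aromatic ring. The same change has been seen once already, on the bromo branch of the series, where the step in this assay is a number 0.76 log units higher from compound 1 to compound 2 (beyond the scatter). Within the data shown here, no second example of this change is available, so the expectation rests on that single step alone.

On that basis the number for compound 4 is expected to rise by about the same amount, with the estimated step from compound 3 being a number 0.76 log units higher from compound 3 to compound 4 (beyond the scatter). Compound 4 is therefore estimated at 6.24 in this assay, within a range of 5.8 to 6.7, before the measurement is in hand.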

Compound 4, partition coefficient: 6.2
Compound 4: middle estimate off by 0.04 log units, on the high side, and the stated range covers the measured number.
By their numbers in this assay, from the lowest: compound 3; then compounds 1 and 4 (each within the scatter of the next); then compound 2.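

In this assay the change to naphthalen-2-yl in place of 4-methylphenyl on an oxygen on an aromatic ring now has a second example, on the fluoro branch, with a number 0.72 log units higher from compound 3 to compound 4 (beyond the scatter) and, on the bromo branch, a number 0.76 log units higher from compound 1 to compound 2 (beyond the scatter) as a step of much the same size, so the change no longer rests on one pair. Fluoro in place of bromo on an aromatic carbon can now also be read with both groups on the oxygen, giving a number 0.73 log units lower from compound 2 to compound 4 (beyond the scatter) with naphthalen-2-yl and a number 0.69 log units lower from compound 1 to compound 3 (beyond the scatter) with 4-methylphenyl, so the two changes add across compounds 1 to 4 and none of the four goes against this. Nothing available here bears on the origin of these steps.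

Within the data shown here, these four compounds cover only two groups at each of the two places, so it remains open whether the same steps would hold with chloro on the aromatic carbon. As far as these compounds go, it also remains open whether a phenyl group carrying an amine or a carboxylic acid on the oxygen would fit the same additive reading.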